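The compounds below may be only part of what the source reports. "The series", "measured", "known", "first", "only" and "open" are said of these compounds alone.

Of the compounds shown here, two have been measured in a functional assay on HCT-116 cells (Homo sapiens) for inhibition; on this read-out lower numbers stand for stronger inhibition and higher numbers for weaker inhibition. Compound 1 `CCNC(=O)c1noc(-c2cc(C(C)C)c(O)cc2O)c1-c1cc(CNCCO)no1` gives 111 nM. Within the data shown here, compound 2 `CCNC(=O)c1noc(-c2cc(C(C)C)c(O)cc2O)c1-c1cc(C(N)=O)no1` gives 79 nM, the lowest of the two numbers; its only neighbour is compound 1, and the step of a 1.4-fold lower number from compound 1 to compound 2 (0.15 log units; within the scatter) is within the scatter, so the two cannot be ordered.

Compound 3 `CCNC(=O)c1noc(-c2cc(C(C)C)c(O)cc2O)c1-c1cnn(CC)c1` has not yet been measured. It differs from compound 2 in one place: 1-ethyl-1H-pyrazol-4-yl in place of 3-carbamoyl-1,2-oxazol-5-yl on an aromatic carbon. Among the measured compounds shown here, the only measured step, a 1.4-fold lower number from compound 1 to compound 2 (0.15 log units; within the scatter), changed a group sitting on the ring that is now exchanged, and it left the number where it was; it is the sole point of reference and bears on the new change only loosely, since here the whole ring is replaced rather than a group on it. For the measured compounds named here, no measured step covers such a ring exchange. The expectation is therefore a step of a 1.9-fold higher number from compound 2 to compound 3 (0.28 log units; within the scatter) of little size, with a wide range to allow for the untested change. For compound 3 the estimate in this assay is 150 nM, expected to lie between 50 nM and 500 nM.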

Compound 3, half-maximal inhibitory concentration: 26 nM
For compound 3 the middle estimate is 5.8-fold (0.76 log units) above the measured one, outside the stated range (below it).
By their numbers in this assay, from the lowest: compound 3; then compounds 2 and 1 (each within the scatter of the next).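

In this assay, exchanging the whole ring gives a 3.0-fold lower number from compound 2 to compound 3 (0.48 log units; beyond the scatter), and the same ring in place of the side-chain-bearing 3-(((2-hydroxyethyl)amino)methyl)-1,2-oxazol-5-yl gives a 4.3-fold lower number from compound 1 to compound 3 (0.63 log units; beyond the scatter); unlike the earlier swap of a group on the 1,2-oxazole ring, both steps lie beyond the scatter. This position, on an aromatic carbon next to the ring atom that bears an ethylcarbamoyl group, therefore responds measurably to what is placed there, and among these three compounds the number is lowest with 1-ethyl-1H-pyrazol-4-yl, which has no hydrogen-bond donor, so neither the carbamoyl group nor the hydroxyethylamino chain is needed for inhibition at this level. Nothing available here accounts for why the number falls with this exchange.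

The ring and its substituent changed together, so these compounds do not separate the part played by the ring itself from that of its ethyl group. A methyl group or a longer chain such as propyl in place of that ethyl, or an amine or a carboxylic acid carried on the same ring, would show how far the trend extends.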